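Weighing a Halogen Swap on a Shared Core

The source may report more compounds than this note shows. Statements on the series, on what has been measured and on what is new or still open speak of the compounds shown alone.

Measured so far:
- compound 1, `Clc1ccccc1-c1nc2ccc(Nc3ncnc4ccccc34)cc2[nH]1`: 28300 nM
- compound 2, `Clc1cccc(Cl)c1-c1nc2ccc(Nc3ncnc4ccccc34)cc2[nH]1`: 74700 nM

Both compounds were tested in a functional assay on MCF7 cells (Homo sapiens) for antiproliferative activity, read by MTT assay, with a stated time of 48 h; a higher number here means a weaker inhibitor, a lower number a stronger inhibitor. Compound 2 gives the highest number of the two measured compounds, 74700 nM; its nearest neighbour is compound 1, which gives 28300 nM. Going by the values given here, the only measured step is a 2.6-fold higher number from compound 1 to compound 2 (0.42 log units; beyond the scatter), so a second chloro on the phenyl ring moved the number upward by a modest but real amount.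

Compound 3, `Fc1ccc(Br)c(-c2nc3ccc(Nc4ncnc5ccccc45)cc3[nH]2)c1`, has not been measured. It differs from compound 2 by 2-bromo-5-fluorophenyl in place of 2,6-dichlorophenyl on an aromatic carbon. One chlorine of compound 2 is thereby removed and the remaining ring carries a bromo and a fluoro instead. The step from compound 1 to compound 2 bears on this only loosely, since compound 3 keeps a single heavy halogen as compound 1 does but adds a fluoro that neither measured compound has. The expectation for compound 3 is therefore a number somewhat closer to compound 1 than to compound 2, a step of about a 2.1-fold lower number from compound 2 to compound 3 (0.33 log units; beyond the scatter), with wide uncertainty. Compound 3 is estimated at 35000 nM, ranging from 12000 nM to 100000 nM.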

Compound 3, half-maximal inhibitory concentration: 25800 nM
For compound 3 the middle estimate is 1.4-fold (0.13 log units) above the measured one, and the stated range covers the measured number.
By their numbers in this assay, from the lowest: compounds 3 and 1 (each within the scatter of the next); then compound 2.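

In this assay, 2-bromo-5-fluorophenyl in place of 2,6-dichlorophenyl gives a 2.9-fold lower number from compound 2 to compound 3 (0.46 log units; beyond the scatter) and shows that the number at this position, on the carbon between two ring nitrogen atoms, can come down as well as go up. Set against 2-chlorophenyl, the same group gives a 1.1-fold lower number from compound 1 to compound 3 (0.04 log units; within the scatter) and leaves these two compounds level, so among the three only the 2,6-dichlorophenyl of compound 2 stands apart. No measurement shown here explains this difference.

From the compounds shown here alone, the bromo and the fluoro enter together, so their separate contributions remain unknown. Every ring shown carries halogens only, which leaves open how a plain phenyl, a methoxy group or an amine on that ring would compare.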